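The source may report more compounds than this note shows. Statements on the series, on what has been measured and on what is new or still open speak of the compounds shown alone.

Measured compounds:
compound 1 `COc1ccc2nc(NC(=O)CNC(=O)c3nn(-c4ccccc4)c(=O)c4ccccc34)sc2c1` — 210 nM
compound 2 `O=C(CNC(=O)c1nn(-c2ccc(F)cc2)c(=O)c2ccccc12)Nc1nc2ccc(Cl)cc2s1` — 25 nM

In an assay on L cells for inhibition of Protein-serine O-palmitoleoyltransferase porcupine (Mus musculus), read by reporter gene assay, with a stated time of 24 h (on this read-out higher numbers stand for an effect only at larger amounts of compound and lower numbers for an effect already at smaller amounts), compound 2 gives 25 nM, the lowest of the two numbers shown, and compound 1 gives 210 nM, a gap that lies beyond the scatter. Compound 1 and compound 2 differ from each other in more than one place, so the two values alone do not tell which part of the difference matters.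

Compound 3 `COc1ccc2nc(NC(=O)CNC(=O)c3nn(-c4ccc(F)cc4)c(=O)c4ccccc34)sc2c1` has not yet been tested in this assay. It differs from compound 2 by a single change: methoxy in place of chloro on an aromatic carbon. Within the data shown here, no measured pair separates this change on its own. Since compound 1, which also carries the methoxy group, gives 210 nM, compound 3 is expected to move toward a higher number, by a step of a 3.2-fold higher number from compound 2 to compound 3 (0.51 log units; beyond the scatter) that may exceed the scatter. The estimate for compound 3 in this assay is 80 nM, with a range from 30 nM to 250 nM.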

Compound 3, half-maximal effective concentration: 90 nM
For compound 3 the middle estimate is 1.1-fold (0.05 log units) below the measured one; the measured number falls inside the stated range.
By their numbers in this assay, from the lowest: compound 2; then compound 3; then compound 1.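

In this assay the change from 6-chloro-1,3-benzothiazol-2-yl to 6-methoxy-1,3-benzothiazol-2-yl now stands on its own, and methoxy in place of chloro gives a 3.6-fold higher number from compound 2 to compound 3 (0.56 log units; beyond the scatter) with the rest of the molecule unchanged. Compound 3 also separates a second place, where fluoro in place of hydrogen on an aromatic carbon gives a 2.3-fold lower number from compound 1 to compound 3 (0.37 log units; beyond the scatter) and so shows that this place too carries a step beyond the scatter, something the two earlier compounds could not show apart. Nothing measured here speaks to what lies behind either step. The compounds shown leave open how an amine or a nitrile would read in place of chloro on this aromatic carbon. They also leave open whether fluoro in place of hydrogen gives a similar step when chloro rather than methoxy is present.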